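One Substituent Swap on an Aromatic Ring

A few compounds are considered here, and "the series" means these few. Any claim that something is new, unique, unknown or untested is made for them only; others in the source may bear on it.

Measured compounds:
- Compound 1 `Cc1cc(C(=O)O)c(C)n1C` in an assay on cells for inhibition of Palmitoleoyl-protein carboxylesterase NOTUM variant C330S (Homo sapiens), read by fluorescence, with a stated time of 40 min (on this read-out higher numbers stand for weaker inhibition and lower numbers for stronger inhibition), gives a limit of the assay, > 100000 nM.
- Compound 2 `Cc1cc(C(=O)O)c(C)n1-c1cccc(F)c1` in this assay gives 1500 nM.

Among the measured compounds shown here, compound 2 holds the only true number here; compound 1 sits at the limit of > 100000 nM in this assay, at which 1 of the 2 values shown sits, which is a limit and not a measurement. Compound 3 `Cc1cc(C(=O)O)c(C)n1-c1cccc(C(F)(F)F)c1` differs from compound 2 by trifluoromethyl in place of fluoro on an aromatic carbon, meta to a large group. No step of this kind has been measured among these compounds, so nothing fixes its size. A modest gain in inhibition is expected, as the step of a 2.5-fold lower number from compound 2 to compound 3 (0.40 log units; beyond the scatter). Compound 3 is therefore estimated at 600 nM, within 150 nM to 3000 nM.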

Compound 3, half-maximal inhibitory concentration: 1500 nM
Compound 3: the middle estimate sits 2.5-fold (0.40 log units) below what was measured; measured number inside the range.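

In this assay there is no change at the digits printed from compound 2 to compound 3 (within the scatter). At this aromatic carbon, then, trifluoromethyl with 4 heavy atoms reads the same as fluoro with 1 heavy atom, so this read-out accepts either group here. Nothing available here explains why the two groups read alike. The compounds shown leave open whether an amine or a methoxy group on this same carbon would read differently. They also leave open whether fluoro and trifluoromethyl would still match on another carbon of the ring.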